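This account rests on a few compounds, and the source may have more. Where it says the series, first, only, none or still open, it means among the compounds named here.

Of the compounds shown here, three sharing one large fused core have been tested, and each differs from the others only in a single group on an aromatic carbon. Compound 1 `CO[C@@H]1[C@H](N(C)c2ncc(-c3c[nH]c4ccc(F)cc34)s2)C[C@H]2O[C@]1(C)n1c3ccccc3c3c4c(c5c6cc(Cl)ccc6n2c5c31)C(=O)NC4` carries a fluoro group there, compound 2 `CO[C@@H]1[C@H](N(C)c2ncc(-c3c[nH]c4ccc(Br)cc34)s2)C[C@H]2O[C@]1(C)n1c3ccccc3c3c4c(c5c6cc(Cl)ccc6n2c5c31)C(=O)NC4` carries bromo in place of fluoro on that aromatic carbon, and compound 3 `COc1ccc2[nH]cc(-c3cnc(N(C)[C@@H]4C[C@H]5O[C@@](C)([C@@H]4OC)n4c6ccccc6c6c7c(c8c9cc(Cl)ccc9n5c8c64)C(=O)NC7)s3)c2c1` carries methoxy in place of fluoro on the same carbon. In a functional assay on HL-60 cells (Homo sapiens) for antiproliferative activity, read by CellTiter-Glo, with a stated time of 72 h (a lower number here means a stronger inhibitor, a higher number a weaker inhibitor), compound 1 gives only a limit of the assay, > 10000 nM. In this assay compound 2 likewise gives only a limit, > 10000 nM. Compound 3 also gives only a limit, > 10000 nM. For the measured compounds named here, because all three values sit at the limit of > 10000 nM in this assay, at which 3 of the 3 values shown sit, none of the measured steps can be sized: a step that the two limits leave unreadable from compound 1 to compound 2, a step that the two limits leave unreadable from compound 1 to compound 3 and a step that the two limits leave unreadable from compound 2 to compound 3 remain unreadable. Compound 2 therefore stands at the limit, with no number of its own. Going by the values given here, compound 4 `CO[C@@H]1[C@H](N(C)c2ncc(-c3c[nH]c4ccc(Br)cc34)s2)C[C@H]2O[C@]1(C)n1c3ccccc3c3c4c(c5c6cc(Br)ccc6n2c5c31)C(=O)NC4` differs from compound 2 by bromo in place of chloro on an aromatic carbon, a change at a different part of the core from the one the measured steps explored, so no measured step bears directly on it. With every measured relative at the limit, compound 4 is expected to stay there as well, an estimated 15000 nM, between 5000 nM and 50000 nM. The step from compound 2 to compound 4 that this implies, a step that the limit leaves unreadable from compound 2 to compound 4, is expected to be unreadable rather than a real change.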

Compound 4, half-maximal inhibitory concentration: > 10000 nM
Compound 4 ended at the assay's limit; the forecaster's own chance of this, stated with the estimate: 85%; the middle value is on the limit's open side.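

Compound 2 and compound 4 each end at a limit of the assay and not at a number, so the step between them cannot be read: the limit of > 10000 nM in this assay, at which 4 of the 4 values shown sit.

The compounds shown leave open whether any group on either of the two aromatic carbons varied here would give a measurable value on the shared core.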